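The compounds below may be only part of what the source reports. "The series", "measured", "known", "first", "only" and "open" are said of these compounds alone.

Compound 1 `Cc1cc(C)c(S(=O)(=O)N2CCC(N3CCC(CCC#N)CC3)CC2)c(C)c1` and compound 2 `Cc1cc(C)c(S(=O)(=O)N2CCC(C(=O)N3CCC(C)CC3)CC2)c(C)c1` share a common core and were both tested in a functional assay on DLD-1 cells (Homo sapiens) for antiproliferative activity, read by CellTiter-Glo, with a stated time of 72 h; on this read-out lower numbers stand for stronger inhibition and higher numbers for weaker inhibition. In this assay compound 1 returns > 5000 nM, which is a limit of the assay rather than a number. In this assay compound 2 likewise returns a limit, > 5000 nM, so no number is available for it. Compound 2 therefore stands at the same bound as the only other measured compound, and nothing shown separates the two. Compound 3 `Cc1cc(C)c(S(=O)(=O)N2CCC(N3CCCCC3)CC2)c(C)c1` has not yet been measured. It differs from compound 2 in one place: piperidin-1-yl in place of (4-methylpiperidin-1-yl)carbonyl on a saturated ring carbon, in words piperidin-1-yl in place of (4-methylpiperidin-1-yl)carbonyl on a saturated ring carbon. Among the compounds with values here, no step between two measured compounds exists in this assay, so no size can be read from a neighbouring pair. Because both shown values sit together at the bound described by the limit of > 5000 nM in this assay, at which 2 of the 2 values shown sit, compound 3 is expected to remain there too, with a step that the limit leaves unreadable from compound 2 to compound 3 that means nothing beyond the scatter. Compound 3 is estimated at 10000 nM, in the range 3000 nM to 50000 nM.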

Compound 3, half-maximal inhibitory concentration: 2200 nM
For compound 3 the middle estimate is 4.5-fold (0.66 log units) above the measured one; measured number below the stated range.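

In this assay, within the data shown here, this place, three ring bonds from the ring nitrogen, now yields a real number for the first time, and putting piperidin-1-yl in place of (4-methylpiperidin-1-yl)carbonyl gives an at least 2.2-fold lower number from compound 2 to compound 3 (0.35 log units; beyond the scatter). Hydrogen in place of 2-cyanoethyl on a saturated ring carbon gives an at least 2.2-fold lower number from compound 1 to compound 3 (0.35 log units; beyond the scatter), so two different changes both lead from a limit of the assay to the same measurable compound. Compound 3 is thus the only one of the three shown with a number, while the other two remain at a limit: the limit of > 5000 nM in this assay, at which 2 of the 3 values shown sit.

The true size of both steps cannot be read, and nothing shown separates the loss of the carbonyl from the loss of the methyl group in the step from compound 2, as the two leave together. From the compounds shown here alone, it also remains open whether a methyl group, an amine or a carboxylic acid placed on the piperidin-1-yl ring of compound 3 would keep its number, or whether a shorter chain than 2-cyanoethyl would already be enough to lose it.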